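Swapping a Dichlorobenzyl for a Fluorobenzyl on One Core

The source may hold more compounds than are shown below. What is called first, only, known or untested is meant among the compounds shown, and "the series" means these compounds.

Compound 1 `Nc1cc(N)c2nc(-c3ccccc3)c(NCc3ccc(Cl)c(Cl)c3)nc2c1` was tested in a functional assay on MDA-MB-435 cells (Homo sapiens) for inhibition, read by sulforhodamine B assay, with a stated time of 48 h; on this read-out lower numbers stand for higher toxicity in this test and higher numbers for lower toxicity in this test. In this assay compound 1 gives 52500 nM, the highest of the two plain numbers in the set. Compound 2 `COc1cc(CNc2nc3cc(N)cc(N)c3nc2-c2ccccc2)cc(OC)c1OC` gives 2880 nM, a lower number, and this gap lies beyond the usual scatter of the method. Compound 3 `CCOC(=O)[C@H](CCC(=O)O)NC(=O)c1ccc(CNc2nc3cc(N)cc(N)c3nc2-c2ccccc2)cc1` is reported only as a limit of the assay, < 100000 nM, not as a number. The unmeasured compound 4 `Nc1cc(N)c2nc(-c3ccccc3)c(NCc3ccc(F)cc3)nc2c1` differs from compound 1 in a single place: 4-fluorophenyl in place of 3,4-dichlorophenyl on a saturated chain carbon bound to a nitrogen on an aromatic ring. Within the data shown here, no measured pair shows a change of this kind, so the expectation rests on compound 1 alone. The step of a 1.2-fold lower number from compound 1 to compound 4 (0.07 log units; within the scatter) is expected to stay within the scatter. Compound 4 is therefore estimated at 45000 nM, with a range from 15000 nM to 120000 nM.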

Compound 4, concentration lethal to 50% of the cells: 6920 nM
Compound 4: middle estimate off by 6.5-fold (0.81 log units), on the high side; measured number outside the range, below it.
By their numbers in this assay, from the lowest: compound 2; then compound 4; then compound 1.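

In this assay the swap from 3,4-dichlorobenzyl to 4-fluorobenzyl gives a 7.6-fold lower number from compound 1 to compound 4 (0.88 log units; beyond the scatter) and so shows that the read-out responds to the substituents on this ring. The earlier compounds shown here could not show this, since no two of them differed in one place alone. Nothing shown accounts for the size of this step. As far as these compounds go, it remains open whether losing the chlorines or gaining the fluorine carries the step. From the compounds shown here alone, how a plain benzyl group, or an amine on that ring, would behave also remains open.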